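The compounds below may be only part of what the source reports. "The series", "measured", "known", "first", "only" and "open" are said of these compounds alone.

Measured in a functional assay on MV4-11 cells (Homo sapiens) for inhibition, read by CellTiter-Glo, with a stated time of 48 h; on this read-out lower numbers stand for stronger inhibition of growth and higher numbers for weaker inhibition of growth:
- compound 1 `O=C(CCCCC(=O)N1C/C=C/COCc2cccc(c2)-c2ccnc(n2)Nc2cccc(c2)C1)NO`: 2060 nM
- compound 2 `O=C(CCCCN1C/C=C/CCOc2cccc(c2)-c2ccnc(n2)Nc2cccc(c2)C1)NO`: 660 nM

Compound 1 has the higher number of these two, and its gap to compound 2 lies beyond the usual scatter. Compound 3 `O=C(CCCCCCN1C/C=C/COCc2cccc(c2)-c2ccnc(n2)Nc2cccc(c2)C1)NO` keeps the core of compound 1 but carries 6-(hydroxycarbamoyl)hexyl in place of (4-(hydroxycarbamoyl)butyl)carbonyl on an amine nitrogen in a ring. Among the measured compounds shown here, no measured pair shows this change alone, so any forecast stays loose. In this assay, an estimated step of a 4.6-fold lower number from compound 1 to compound 3 (0.66 log units; beyond the scatter) is expected, towards a lower number and beyond the scatter. For compound 3 the estimate is 450 nM, with an expected range from 120 nM to 1600 nM.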

Compound 3, concentration for 50% growth inhibition: 320 nM
The estimate for compound 3 lay 1.4-fold (0.15 log units) above the measured number; the range from low to high includes it.
By their numbers in this assay, from the lowest: compound 3; then compound 2; then compound 1.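

In this assay, placing 6-(hydroxycarbamoyl)hexyl instead of (4-(hydroxycarbamoyl)butyl)carbonyl on the amine nitrogen in the ring gives a 6.4-fold lower number from compound 1 to compound 3 (0.81 log units; beyond the scatter), so the group at this position matters with the core of compound 1 held constant. Both groups carry hydroxycarbamoyl and no ring, but the carbonyl attached to that nitrogen is gone in the entering group. Nothing shown here explains the lower number. Still open, on these data alone, is how a longer chain, such as 8-(hydroxycarbamoyl)octyl, would read on this nitrogen. Also open, as far as these compounds go, is whether a carboxylic acid in place of hydroxycarbamoyl would retain growth inhibition.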